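The source may report more compounds than this note shows. Statements on the series, on what has been measured and on what is new or still open speak of the compounds shown alone.

Measured so far in a functional assay on FM3A cells (Mus musculus) for cytotoxicity; a higher number here means that more compound is needed for the effect, a lower number that less compound is needed
Compound 1 `C=C(C)COOC1(OOC)CCCCCCCCCCC1` gives 17000 nM
Compound 2 `COOC1(OOC(C)(C)OC)CCCCCCCCCCC1` gives 7300 nM
Compound 3 `COOC1(OOCCCCCC(=O)O)CCCCCCCCCCC1` gives 14000 nM

These three share one core and differ in the group carried on one oxygen. For the measured compounds named here, only one step among them clears the usual scatter, and it is modest: a 2.3-fold lower number from compound 1 to compound 2 (0.37 log units; beyond the scatter) in this series. Compound 3 cannot be told apart from either of the others, with a 1.2-fold lower number from compound 1 to compound 3 (0.08 log units; within the scatter) on one side and a 1.9-fold higher number from compound 2 to compound 3 (0.28 log units; within the scatter) on the other.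

The next compound is compound 4 `COOC1(OOCCC(=O)OC)CCCCCCCCCCC1` in which 5-carboxypentyl becomes 2-(methoxycarbonyl)ethyl. The counted change is methoxycarbonyl in place of 3-carboxypropyl on a saturated chain carbon, two bonds along the chain from an oxygen and in words it is methoxycarbonyl in place of 3-carboxypropyl on a saturated chain carbon, two bonds along the chain from an oxygen. Going by the values given here, no compound with this ester has been measured, so the only guide is how little the number has moved when this group was swapped. The largest such swap gave a 2.3-fold lower number from compound 1 to compound 2 (0.37 log units; beyond the scatter) and the two swaps involving compound 3 stayed within the scatter. No clear direction follows from these, so the expected change is small, and the estimate is a 1.1-fold lower number from compound 3 to compound 4 (0.03 log units; within the scatter) in this assay as a working figure. Compound 4 is estimated at 13000 nM with an expected range from 6000 nM to 28000 nM in this estimate.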

Compound 4, half-maximal effective concentration: 1400 nM
The estimate for compound 4 lay 9.3-fold (0.97 log units) above the measured number; the measured number lies below the stated range.
By their numbers in this assay, from the lowest: compound 4; then compounds 2, 3 and 1 (each within the scatter of the next, the first and the last beyond it).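

In this assay, the group at this position matters more than the first three compounds suggested: methoxycarbonyl in place of 3-carboxypropyl, on a saturated chain carbon, two bonds along the chain from an oxygen, gives a 10-fold lower number from compound 3 to compound 4 (1.00 log units; beyond the scatter), well past the largest earlier step, a 2.3-fold lower number from compound 1 to compound 2 (0.37 log units; beyond the scatter). For the compounds shown here, the new compound also separates from the other two, with a 5.2-fold lower number from compound 2 to compound 4 (0.72 log units; beyond the scatter) and a 12-fold lower number from compound 1 to compound 4 (1.08 log units; beyond the scatter), so compound 4 is the only one here whose steps to all the others lie beyond the scatter, and it needs the least compound for the effect. No supporting measurement accompanies this result, so the size of the drop stands as an observation without an explanation.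

This single change shortens the chain and also replaces the carboxylic acid with a methyl ester, so the compounds shown cannot separate the two. A carboxylic acid on the shorter chain of compound 4, or a methyl ester on the longer chain of compound 3, would show which of the two changes goes with the lower number.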